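The compounds below may be only part of what the source reports. "The series", "measured", "known", "first", "only" and "open" are said of these compounds alone.

Measured in a functional assay on DU-145 cells (Homo sapiens) for inhibition, read by trypan blue exclusion, with a stated time of 96 h; on this read-out lower numbers stand for stronger inhibition of growth and higher numbers for weaker inhibition of growth:
- compound 1 `O=C(/C(=C\c1ccc(Br)c(O)c1)S(=O)(=O)c1ccc(Br)cc1)c1ccc(Br)cc1`: 50000 nM
- compound 2 `O=C(/C(=C\c1c[nH]c2ccccc12)S(=O)(=O)c1ccc(Br)cc1)c1ccc(Br)cc1`: 25000 nM

Only these two compounds have been measured so far, and their values lie within the scatter of each other, so compound 2 cannot be ranked ahead of compound 1. Compound 3 `Nc1c(Br)cc(Br)cc1/C=C(\C(=O)c1ccc(Br)cc1)S(=O)(=O)c1ccc(Br)cc1` has 2-amino-3,5-dibromophenyl in place of the 1H-indol-3-yl of compound 2, on a double-bonded chain carbon bound to a double-bonded chain carbon: 2-amino-3,5-dibromophenyl in place of 1H-indol-3-yl on a double-bonded chain carbon bound to a double-bonded chain carbon. Among the measured compounds shown here, one measured step bears on this, since it changes the group at that same place: a 2.0-fold lower number from compound 1 to compound 2 (0.30 log units; within the scatter). That single step gives no sign of a large change, although it is thin evidence. An estimated no change at the digits printed from compound 2 to compound 3 (within the scatter) is therefore expected in this assay, which means no step beyond the scatter. The expected value for compound 3 is 25000 nM, within an estimated range of 8000 nM to 70000 nM.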

Compound 3, concentration for 50% growth inhibition: 25000 nM
The estimate for compound 3 equals the measured number at the digits printed; the range from low to high includes it.
By their numbers in this assay, from the lowest: compounds 2, 3 and 1 (each within the scatter of the next).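

Changing from 1H-indol-3-yl to 2-amino-3,5-dibromophenyl gives no change at the digits printed from compound 2 to compound 3 (within the scatter) in this assay, so at this place on a double-bonded chain carbon, a single six-membered aromatic ring carrying bromine cannot be told apart from the indole group, with its five-membered aromatic ring. Against 4-bromo-3-hydroxyphenyl, the same group gives a 2.0-fold lower number from compound 1 to compound 3 (0.30 log units; within the scatter), which means that all three groups at this place now read alike within the scatter. No measurement shown explains why these different groups give such similar numbers.

From the compounds shown here alone, it remains open whether a group without a ring at this place, such as an amine, a carboxylic acid or a longer chain, would stand apart from these three. Going by these compounds, it is also open whether these three groups would still read alike on another cell line.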